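This account rests on a few compounds, and the source may have more. Where it says the series, first, only, none or still open, it means among the compounds named here.

Three compounds share one core and differ only in the group carried on an aromatic carbon. Compound 1 `COc1cc2ncnc(-n3nc(-c4ccccn4)nc3N)c2cc1N` carries an amino group there. In an assay on MCF7 cells for inhibition of Serine-protein kinase ATM (Homo sapiens), read by immunofluorescence, with a stated time of 1 h (a lower number here means a stronger inhibitor, a higher number a weaker inhibitor), compound 1 reaches only a limit, > 40000 nM. Compound 2 `COc1cc2ncnc(-n3nc(-c4ccccn4)nc3N)c2cc1OCCCN1CC(C)OC(C)C1` carries a 3-(2,6-dimethylmorpholin-4-yl)propoxy chain in its place and in this assay gives 1600 nM. Compound 3 `CCOC(=O)NCCCOc1cc2c(-n3nc(-c4ccccn4)nc3N)ncnc2cc1OC` carries a 3-((ethoxycarbonyl)amino)propoxy chain and gives 800 nM. Putting a chain in place of the amino group brings an at least 25-fold lower number from compound 1 to compound 2 (1.39 log units; beyond the scatter) and an at least 50-fold lower number from compound 1 to compound 3 (1.69 log units; beyond the scatter); between the two chains the difference is only a 2.0-fold lower number from compound 2 to compound 3 (0.30 log units; within the scatter). Compound 3 thus holds the lowest of the two numbers, with compound 2 within the scatter of it.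

Compound 4 `COc1cc2ncnc(-n3nc(-c4ccccn4)nc3N)c2cc1OCCCNC(=O)C(F)(F)F` keeps the chain of compound 3 and changes only the group on the carbonyl carbon: trifluoromethyl in place of ethoxy on a carbonyl carbon. Going by the values given here, no measured step alters a group on this carbonyl carbon. Among the compounds with values here, the only step that exchanges the group carried by the chain, a 2.0-fold lower number from compound 2 to compound 3 (0.30 log units; within the scatter), stayed within the scatter although whole groups were swapped, while the large steps of an at least 25-fold lower number from compound 1 to compound 2 (1.39 log units; beyond the scatter) and an at least 50-fold lower number from compound 1 to compound 3 (1.69 log units; beyond the scatter) concern the chain itself, which compound 4 keeps. The expected step is therefore small, a 1.3-fold higher number from compound 3 to compound 4 (0.10 log units; within the scatter), with no firm direction. Compound 4 is estimated at 1000 nM, in a range from 400 nM to 2500 nM.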

Compound 4, half-maximal inhibitory concentration: 2900 nM
For compound 4 the middle estimate is 2.9-fold (0.46 log units) below the measured one, and the stated range ends below it.
By their numbers in this assay, from the lowest: compounds 3, 2 and 4 (each within the scatter of the next, the first and the last beyond it). At a limit, above all of these: compound 1.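

Going by these compounds alone, changing the group on the carbonyl carbon, which no earlier pair of compounds had tested, does shift the number in this assay: with trifluoromethyl in place of ethoxy there is a 3.6-fold higher number from compound 3 to compound 4 (0.56 log units; beyond the scatter), so this end of the chain is not indifferent to what it carries, even though the earlier exchange of whole end groups stayed within the scatter. The cost is limited, since the step to the chain ending in 2,6-dimethylmorpholin-4-yl gives a 1.8-fold higher number from compound 2 to compound 4 (0.26 log units; within the scatter), and the chain as a whole still outweighs the amino group, with an at least 13-fold lower number from compound 1 to compound 4 (1.13 log units; beyond the scatter). That last step gives only a lower bound on the gain, because compound 1 stands at a limit and not at a number: the limit of > 40000 nM in this assay, at which 1 of the 4 values shown sits.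

With only ethoxy and trifluoromethyl on this carbonyl carbon, a single step cannot show whether the oxygen and ethyl of the one or the fluorines of the other drive the difference, and a methyl, a methoxy or a tert-butyl in the same place would help to separate them. Also open, going by these compounds, is whether the same exchange would have the same size on a longer chain.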